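The source may report more compounds than this note shows. Statements on the series, on what has been measured and on what is new or still open speak of the compounds shown alone.

Measured so far:
compound 1 `O=C(O)CC/C=C\CC1COC(c2ccc(Cl)cc2Cl)OC1c1cccnc1` — 891 nM
compound 2 `CC(C)(C)c1ccc(OC(C)(C)C2OCC(C/C=C\CCC(=O)O)C(c3cccnc3)O2)cc1` — 1910 nM

Of the compounds shown here, two have been measured in a functional assay for inhibition, with Homo sapiens as the target; on this read-out lower numbers stand for tighter binding and higher numbers for weaker binding. Compound 1 `O=C(O)CC/C=C\CC1COC(c2ccc(Cl)cc2Cl)OC1c1cccnc1` gives 891 nM in this assay. Compound 2 `CC(C)(C)c1ccc(OC(C)(C)C2OCC(C/C=C\CCC(=O)O)C(c3cccnc3)O2)cc1` gives 1910 nM in this assay and stands highest of the two numbers; its nearest neighbour is compound 1, whose number is lower by a margin that lies beyond the usual scatter of such measurements.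

Compound 3 `CC(C)(Cc1ccc(F)cc1)C1OCC(C/C=C\CCC(=O)O)C(c2cccnc2)O1` has not yet been measured in this assay. It differs from compound 2 in one place: 4-fluorobenzyl in place of 4-(tert-butyl)phenoxy on a saturated chain carbon bound to two saturated chain carbons and a saturated ring carbon. Going by the values given here, neither measured compound shows a change of this kind, so no measured step bears directly on it; compound 1 and compound 2 differ in several places at once and only show that the two numbers sit fairly close to each other.

With that in mind, the step from compound 2 to compound 3 in this assay is expected to be small, a step of a 1.3-fold lower number from compound 2 to compound 3 (0.10 log units; within the scatter), which would not go beyond the scatter. Compound 3 is therefore expected to give about 1500 nM in this assay, within a range from 450 nM to 5000 nM.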

Compound 3, dissociation constant: 89.1 nM
Estimate against measurement, compound 3: 17-fold (1.23 log units) above; the whole stated range lies above it.
By their numbers in this assay, from the lowest: compound 3; then compound 1; then compound 2.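

In this assay, putting 4-fluorobenzyl in place of 4-(tert-butyl)phenoxy on a saturated chain carbon bound to two saturated chain carbons and a saturated ring carbon gives a 21-fold lower number from compound 2 to compound 3 (1.33 log units; beyond the scatter) and is a large step. Going by these compounds alone, this is the first measured change at this position, and it shows that the read-out responds strongly to the group held there, which the earlier pair could not show since compound 1 and compound 2 differ in several places at once. Nothing on hand accounts for the size of this step. The step also exchanges several things at once: the oxygen that joins the ring to the chain carbon gives way to a carbon, and the tert-butyl group gives way to fluorine, so the compounds shown leave open which of these parts goes with the lower number. A 4-fluorophenoxy or a 4-(tert-butyl)benzyl group on the same carbon would separate the two, while an unsubstituted benzyl or a longer chain such as 2-(4-fluorophenyl)ethyl would show how much depends on the fluorine and on the length of the link.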